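The source may report more compounds than this note shows. Statements on the series, on what has been measured and on what is new or still open speak of the compounds shown alone.

In an ADME assay on Huh-7 cells (Homo sapiens) for cytotoxicity (a lower number here means that less compound is tolerated, a higher number that more compound is tolerated), compound 1 `C[C@@]1(O)[C@H](O)[C@@H](CO)O[C@H]1c1cnc2c(N)ncnn12` gives 26000 nM, the higher of the two numbers recorded there. Compound 2 `C#Cc1cc([C@@H]2O[C@H](CO)[C@@H](O)[C@@]2(C)O)n2ncnc(N)c12` gives 930 nM, a value that lies beyond the scatter from that of compound 1. For compound 3 `C[C@@]1(O)[C@H](O)[C@@H](CO)O[C@H]1c1c(F)cc2c(N)ncnn12` the assay reports only a limit, > 100000 nM, which is the limit of > 100000 nM in this assay, at which 1 of the 3 values shown sits. Compound 4 `C[C@@]1(O)[C@H](O)[C@@H](CO)O[C@H]1c1cnc2c(N)nc(N)nn12` has not yet been measured; it differs from compound 1 by amino in place of hydrogen on an aromatic carbon, an amino in place of hydrogen on an aromatic carbon. For the measured compounds named here, no measured pair shows this step, so no movement beyond the scatter is expected in either direction. Compound 4 is therefore estimated at 30000 nM in this assay, expected to fall between 8000 nM and 100000 nM. The expected step is a 1.2-fold higher number from compound 1 to compound 4 (0.06 log units; within the scatter), within the scatter.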

Compound 4, half-maximal cytotoxic concentration: > 100000 nM
Compound 4: a limit, no number; the forecaster's own chance of this, stated with the estimate: 25%; at least 3.3-fold (0.52 log units) between middle value and limit.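

Amino in place of hydrogen, on the aromatic carbon between two ring nitrogen atoms, gives an at least 3.8-fold higher number from compound 1 to compound 4 (0.58 log units; beyond the scatter) in this assay, the only single change among these compounds that can be read. This shows that this position is not silent in this assay, and that adding amino here raises the tolerated concentration. Compound 4 gives a limit and not a number, so the step has no upper end: the limit of > 100000 nM in this assay, at which 2 of the 4 values shown sit.

Going by these compounds, what a methylamino group, a hydroxyl or a chlorine on this carbon would give stays open. So does whether amino here acts the same way when the rest of the core differs.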